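This account rests on a few compounds, and the source may have more. Where it says the series, first, only, none or still open, it means among the compounds named here.

In a functional assay on MCF7 cells (Homo sapiens) for antiproliferative activity, read by MTT assay, with a stated time of 24 h (on this read-out higher numbers stand for weaker inhibition and lower numbers for stronger inhibition), compound 3 `CCN(CC)CCNC(=O)c1ccc(C(CC)(CC)c2ccc(OCS(=O)(=O)c3ccccc3)c(C)c2)n1CC` gives 4680 nM and compound 2 `CCn1c(C(=O)NCCN)ccc1C(CC)(CC)c1ccc(OCS(=O)(=O)c2ccccc2)c(C)c1` gives 6470 nM. For the measured compounds named here, these are the only two numbers so far, and a 1.4-fold lower number from compound 2 to compound 3 (0.14 log units; within the scatter) leaves them level. Compound 1 `CCn1c(C(=O)NCC(=O)OC)ccc1C(CC)(CC)c1ccc(OCS(=O)(=O)c2ccccc2)c(C)c1` reads > 50000 nM, which is a limit of the assay and not a number. Compound 4 `CCn1c(C(=O)NCCO)ccc1C(CC)(CC)c1ccc(OCS(=O)(=O)c2ccccc2)c(C)c1` differs from compound 3 by hydroxy in place of diethylamino on a saturated chain carbon, two bonds along the chain from an amide-type nitrogen, with hydroxy in place of diethylamino on a saturated chain carbon, two bonds along the chain from an amide-type nitrogen. The nearest guides are an at least 7.7-fold lower number from compound 1 to compound 2 (0.88 log units; beyond the scatter) and an at least 10-fold lower number from compound 1 to compound 3 (1.02 log units; beyond the scatter), both of which introduced an amino group that compound 4 lacks. Going by the values given here, no measured step involves hydroxy, so only a moderate move to a higher number is expected in this assay. The expected step is a 4.3-fold higher number from compound 3 to compound 4 (0.63 log units; beyond the scatter). For compound 4 the estimated value is 20000 nM, with an expected range of 7000 nM to 50000 nM.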

Compound 4, half-maximal inhibitory concentration: 15500 nM
The estimate for compound 4 lay 1.3-fold (0.11 log units) above the measured number, within the range that was stated.
By their numbers in this assay, from the lowest: compounds 3 and 2 (each within the scatter of the next); then compound 4. At a limit, above all of these: compound 1.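

With hydroxy on this saturated chain carbon the number rises from either amine, a 3.3-fold higher number from compound 3 to compound 4 (0.52 log units; beyond the scatter) and a 2.4-fold higher number from compound 2 to compound 4 (0.38 log units; beyond the scatter), so both amino and diethylamino read lower here than hydroxy. The neutral alcohol is nonetheless not equivalent to the ester end of the chain: with hydroxymethyl in place of methoxycarbonyl there is an at least 3.2-fold lower number from compound 1 to compound 4 (0.50 log units; beyond the scatter). That step is read against a limit and not a number: the limit of > 50000 nM in this assay, at which 1 of the 4 values shown sits.

The compounds shown leave open how a longer chain carrying the amine, a piperidine or a carboxylic acid would read at this place.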